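Swapping Chloro for Acetyl on a Shared Core

The source may hold more compounds than are shown below. What is called first, only, known or untested is meant among the compounds shown, and "the series" means these compounds.

Compound 1 `COc1cc(-c2ccnc3cc(-c4ccc(Cl)cc4)nn23)cc(OC)c1OC` was tested in a functional assay on B16-F0 cells (Mus musculus) for inhibition, read by CCK-8 assay, with a stated time of 48 h (on this read-out higher numbers stand for weaker inhibition and lower numbers for stronger inhibition), where compound 1 gives 4090 nM. Of the two plain numbers shown this is the lowest, yet compound 2 `Cn1ccc2cc(-c3cc4nccc(-c5ccc(F)cc5)n4n3)ccc21`, which in this assay gives 4780 nM, lies within the usual scatter of it, so the two cannot be told apart. Compound 3 `COc1ccc(-c2cc3nccc(-c4cc(OC)c(OC)c(OC)c4)n3n2)cc1[N+](=O)[O-]` reached only a limit of the measurement, (the limit of > 10000 nM in this assay, at which 1 of the 3 values shown sits), and in this assay compound 3 is recorded as > 10000 nM. Compound 4 `COc1cc(-c2ccnc3cc(-c4ccc(C(C)=O)cc4)nn23)cc(OC)c1OC` is not yet measured and differs from compound 1 in one place: acetyl in place of chloro on an aromatic carbon. Among the measured compounds shown here, no measured pair shows this kind of change. The expected step is a 1.1-fold higher number from compound 1 to compound 4 (0.04 log units; within the scatter), no larger than the scatter. For compound 4 the estimated value in this assay is 4500 nM, with a range from 1500 nM to 13000 nM.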

Compound 4, half-maximal inhibitory concentration: 3930 nM
Compound 4: middle estimate off by 1.1-fold (0.06 log units), on the high side; measured number inside the range.
By their numbers in this assay, from the lowest: compounds 4, 1 and 2 (each within the scatter of the next). At a limit, above all of these: compound 3.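

Putting acetyl in place of chloro gives a 1.0-fold lower number from compound 1 to compound 4 (0.02 log units; within the scatter) in this assay, so the two compounds cannot be told apart. Among the compounds shown here, this is the first pair differing in one place, and it shows that this position on the ring carries three heavy atoms and a hydrogen-bond acceptor, rather than one chlorine, with no readable change in the number. No measurement shown offers a reason for this result.

As far as these compounds go, whether an amine, a carboxylic acid or a longer chain at this position would shift the number beyond the scatter remains open.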